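This account rests on a few compounds, and the source may have more. Where it says the series, first, only, none or still open, it means among the compounds named here.

Of the compounds shown here, three built on one shared core have been tested in a functional assay on A549 cells (Homo sapiens) for antiproliferative activity, read by MTT assay, with a stated time of 48 h (a higher number here means a weaker inhibitor, a lower number a stronger inhibitor), and they differ only in a single group on that core. Compound 1 `COc1ccc(-c2nc3cccc(-c4cc(OC)c(OC)c(OC)c4)c3o2)cc1OC` carries 3,4-dimethoxyphenyl and gives 2800 nM, compound 2 `COc1cc(-c2cccc3nc(-c4cccc(F)c4)oc23)cc(OC)c1OC` carries 3-fluorophenyl and gives 2600 nM, and compound 3 `COc1cc(-c2cccc3nc(-c4ccc(C)cc4)oc23)cc(OC)c1OC` carries 4-methylphenyl and gives 680 nM. Compound 3 therefore has the lowest number of the three, and its gaps to both others lie beyond the scatter.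

Compound 4 `COc1cc(-c2nc3cccc(-c4cc(OC)c(OC)c(OC)c4)c3o2)ccc1O` has 4-hydroxy-3-methoxyphenyl in place of 4-methylphenyl on an aromatic carbon. For the measured compounds named here, three measured steps bear on this change. Swapping 3,4-dimethoxyphenyl for 4-methylphenyl gave a 4.1-fold lower number from compound 1 to compound 3 (0.61 log units; beyond the scatter), and swapping 3-fluorophenyl for 4-methylphenyl gave a 3.8-fold lower number from compound 2 to compound 3 (0.58 log units; beyond the scatter). Both are modest. Swapping 3,4-dimethoxyphenyl for 3-fluorophenyl gave a 1.1-fold lower number from compound 1 to compound 2 (0.03 log units; within the scatter). Going by the values given here, the incoming group resembles the one in compound 1, which gives 2800 nM, with a hydroxy group where that compound has a second methoxy group. Among the compounds with values here, no tested compound carries a hydroxy group, so the range must stay wide. A modest step toward a higher number is therefore expected in this assay. The expected step is a 2.9-fold higher number from compound 3 to compound 4 (0.47 log units; beyond the scatter). The estimate for compound 4 is 2000 nM, within a range of 600 nM to 6000 nM.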

Compound 4, half-maximal inhibitory concentration: 15700 nM
For compound 4 the middle estimate is 7.9-fold (0.89 log units) below the measured one; measured number outside the range, above it.
By their numbers in this assay, from the lowest: compound 3; then compounds 2 and 1 (each within the scatter of the next); then compound 4.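

In this assay the smallest edit in the series proves to matter: hydrogen in place of methyl on one oxygen of the 3,4-dimethoxyphenyl group gives a 5.6-fold higher number from compound 1 to compound 4 (0.75 log units; beyond the scatter) and so shows that this position can tell a hydroxy group from a methoxy group, although the earlier swap of 3,4-dimethoxyphenyl for 3-fluorophenyl stayed within the scatter. The new group also compares poorly with the other two, with a 6.0-fold higher number from compound 2 to compound 4 (0.78 log units; beyond the scatter) and with a 23-fold higher number from compound 3 to compound 4 (1.36 log units; beyond the scatter) as the large step, which makes compound 4 the weakest of the four in this assay. No measurement is available that explains why this change weakens the compounds.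

The compounds shown leave open whether the loss follows the hydroxy group wherever it sits on the phenyl ring, or only in the 4-hydroxy-3-methoxyphenyl arrangement, since no compound carries a hydroxy group alone. They also leave open how an amine or a carboxylic acid in that same place would compare with the hydroxy group and with the methoxy group.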